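This account rests on a few compounds, and the source may have more. Where it says the series, first, only, none or still open, it means among the compounds named here.

Measured in a physicochemical assay for solubility, in phosphate buffer, with a stated time of 18 h; a higher number here means a more soluble compound, a lower number a less soluble compound:
- Compound 1 `CC(C)(C)c1nc(CCCCC#N)c2c(N)c(C#N)c(N)nc2n1`: 16000 nM
- Compound 2 `CC(C)(C)c1nc(C2CCCC2)c2c(N)c(C#N)c(N)nc2n1`: < 1000 nM
- Compound 3 `CC(C)(C)c1nc(-c2cccs2)c2c(N)c(C#N)c(N)nc2n1`: 56000 nM

The entry for compound 2 is a limit of the assay, not a number. Compound 3, at 56000 nM, stands highest, and compound 1 is its nearest neighbour. Compound 4 `CC(C)(C)c1nc(-c2ccsc2)c2c(N)c(C#N)c(N)nc2n1` carries thiophen-3-yl in place of thiophen-2-yl on an aromatic carbon. Two measured steps changed the group at this same place: a 3.5-fold higher number from compound 1 to compound 3 (0.54 log units; beyond the scatter), a modest one, and an at least 56-fold higher number from compound 2 to compound 3 (1.74 log units; beyond the scatter), a large one. Neither swaps one thiophene for the other, and here the same atoms are merely joined differently, so only a small change is expected, probably within the scatter. The expected step is a 1.4-fold lower number from compound 3 to compound 4 (0.15 log units; within the scatter). The estimate for compound 4 is 40000 nM, with an expected range of 14000 nM to 100000 nM.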

Compound 4, solubility: 40000 nM
Estimate against measurement, compound 4: no gap at the digits printed; low and high end bracket the measured number.
By their numbers in this assay, from the lowest: compound 1; then compounds 4 and 3 (each within the scatter of the next). At a limit, below all of these: compound 2.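

In this assay, the two ways of joining the thiophene to the shared core cannot be told apart: a 1.4-fold lower number from compound 3 to compound 4 (0.15 log units; within the scatter). With compound 4, a second thiophene stands clear of both non-aromatic groups at this position, with a 2.5-fold higher number from compound 1 to compound 4 (0.40 log units; beyond the scatter) and an at least 40-fold higher number from compound 2 to compound 4 (1.60 log units; beyond the scatter). The entry for compound 2 is a limit, not a number: the limit of < 1000 nM in this assay, at which 1 of the 4 values shown sits.

Still open, as far as these compounds go, is whether a phenyl or pyridyl ring at this position would match the thiophenes. From the compounds shown here alone, it is also open whether a methyl group or an amine on the thiophene would keep these values.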